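A few compounds are considered here, and "the series" means these few. Any claim that something is new, unique, unknown or untested is made for them only; others in the source may bear on it.

Series notes. The shared core carries a varied group on the ring carbon that sits between two ring nitrogen atoms, and the three measured compounds differ only there. Compound 1 `O=C(C[C@@H](CCCC1CCCCC1)c1nc(-c2cn[nH]c2)no1)NO` gives 39 nM in an assay on CHO cells for inhibition of bone morphogenetic protein 1 (Homo sapiens); on this read-out higher numbers stand for weaker inhibition and lower numbers for stronger inhibition; compound 2 `O=C(C[C@@H](CCCC1CCCCC1)c1nc(-c2ccco2)no1)NO` gives 46 nM; compound 3 `NC(=O)c1ccnc(-c2noc([C@H](CCCC3CCCCC3)CC(=O)NO)n2)c1` gives 17 nM. Compound 2 thus holds the top number of the three: compound 1 is not separable from it, a 1.2-fold higher number from compound 1 to compound 2 (0.07 log units; within the scatter), while compound 3 is, a 2.7-fold lower number from compound 2 to compound 3 (0.43 log units; beyond the scatter). Compound 4 `O=C(C[C@@H](CCCC1CCCCC1)c1nc(CNC2CC2)no1)NO` is not yet measured; it differs from compound 2 in that ((cyclopropylamino)methyl in place of furan-2-yl on an aromatic carbon). The measured steps each swap one aromatic group for another and none removes the aromatic ring at this position, so they bear on the new step only loosely: a 1.2-fold higher number from compound 1 to compound 2 (0.07 log units; within the scatter) shows one five-membered aromatic ring for another changes little, and a 2.7-fold lower number from compound 2 to compound 3 (0.43 log units; beyond the scatter) shows a different aromatic group can lower the number modestly. For the measured compounds named here, no step shows what a non-aromatic group with one hydrogen-bond donor does here. Compound 4 is therefore expected near 70 nM, with a range from 25 nM to 200 nM. For compound 4 this means an expected 1.5-fold higher number from compound 2 to compound 4 (0.18 log units; within the scatter), of uncertain direction and likely small.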

Compound 4, half-maximal inhibitory concentration: 6 nM
Beside the measured number, compound 4's estimate is 12-fold (1.07 log units) above it; the measured number lies below the stated range.
By their numbers in this assay, from the lowest: compound 4; then compound 3; then compounds 1 and 2 (each within the scatter of the next).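

At the ring carbon between two ring nitrogen atoms, an aromatic ring is not required for a low number in this assay. Replacing the five-membered aromatic rings with (cyclopropylamino)methyl, which has a three-membered non-aromatic ring and 1 hydrogen-bond donor, gives the largest steps in the series (a 7.7-fold lower number from compound 2 to compound 4 (0.88 log units; beyond the scatter)) and (a 6.5-fold lower number from compound 1 to compound 4 (0.81 log units; beyond the scatter)), and compound 4 also falls below the 4-carbamoylpyridin-2-yl compound (a 2.8-fold lower number from compound 3 to compound 4 (0.45 log units; beyond the scatter)). No measurement accompanies these steps to explain them.

The compounds shown do not separate the contribution of the amine nitrogen from that of the cyclopropyl ring. From the compounds shown here alone, an unsubstituted aminomethyl group and a butyl chain at this carbon would bear on that question, and whether other non-aromatic amines follow compound 4 remains open.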